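The source may report more compounds than this note shows. Statements on the series, on what has been measured and on what is new or still open speak of the compounds shown alone.

Of the compounds shown here, two have been measured so far. Compound 1 `O=C(Nc1ccc(S(=O)(=O)Nc2ccccc2)cc1)c1cc2ccccc2oc1=O` and compound 2 `Cc1cc(Cl)ccc1C(=O)Nc1ccc(S(=O)(=O)Nc2ccccc2)cc1` share a core and differ in the group carried on the amide. In a functional assay on HEK293 cells for agonist activity at probable G-protein coupled receptor 27 (Homo sapiens), read by a luciferase reporter and beta-arrestin recruitment, with a stated time of 10 min (on this read-out lower numbers stand for an effect already at smaller amounts and higher numbers for an effect only at larger amounts of compound), compound 1 gives 7760 nM, while compound 2 gives 912 nM. Compound 2 thus stands at the lower of the two numbers, and the gap to compound 1 lies beyond the scatter, so among the measured pair compound 2 is the one that acts at the smaller amount.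

Compound 3 `O=C(Nc1ccc(S(=O)(=O)Nc2ccccc2)cc1)c1ccc(Cl)cc1Cl` is not yet measured. It differs from compound 2 in one spot: chloro in place of methyl on an aromatic carbon. Read one bond further out, a 4-chloro-2-methylphenyl becomes a 2,4-dichlorophenyl. Going by the values given here, no measured pair shows this exact exchange, so its effect cannot be taken from the numbers at hand. Because compound 2 already gives 912 nM, the expectation is a small step in this assay, most likely none beyond the scatter, if anything slightly toward a lower number. The step from compound 2 to compound 3 is expected to be a 1.3-fold lower number from compound 2 to compound 3 (0.11 log units; within the scatter). Compound 3 is therefore estimated at 700 nM, within a range from 250 nM to 2500 nM.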

Compound 3, half-maximal effective concentration: 457 nM
Compound 3: middle estimate off by 1.5-fold (0.19 log units), on the high side; low and high end bracket the measured number.
By their numbers in this assay, from the lowest: compounds 3 and 2 (each within the scatter of the next); then compound 1.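

In this assay, putting a chloro in place of the methyl, on an aromatic carbon ortho to a large group and meta to a chloro group, amounts to a 2.0-fold lower number from compound 2 to compound 3 (0.30 log units; within the scatter), so the two compounds cannot be told apart at this position. The earlier pair could not show this, since its two members differ in the whole group carried on the amide, whereas here a single heavy atom is exchanged for another single heavy atom and the read-out stays within the usual variation between repeat measurements. No measurement at hand speaks to why methyl and chloro read alike at this spot.

On these data alone, what an amine, a methoxy group or a carboxylic acid would do at this same aromatic carbon remains open, as does the reading with only a hydrogen there, which would show whether any group at this position matters at all. Also open, as far as these compounds go, is whether methyl and chloro would still read alike if the chloro group already on the ring were replaced by, say, a methoxy group.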